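The source may hold more compounds than are shown below. What is called first, only, known or untested is meant among the compounds shown, and "the series" means these compounds.

Measured so far in an assay on isolated protein for displacement of a labelled ligand from Orexin/Hypocretin receptor type 1 (Homo sapiens), with a stated time of 90 min; on this read-out lower numbers stand for stronger inhibition and higher numbers for weaker inhibition:
compound 1 `COc1ccc(N2C(=O)N(Cc3c(F)cc(F)cc3F)c3ccccc3S2(=O)=O)cc1OC` gives 50.1 nM
compound 2 `COc1cc(F)c(CN2C(=O)N(c3cc(OC)nc(OC)c3)S(=O)(=O)c3ccccc32)c(F)c1` gives 1 nM

Of the two numbers, compound 1 has the higher one; compound 2 sits at a lower number, and that gap lies beyond the scatter. Within the data shown here, no step between measured compounds differing in a single place is available, so nothing directly matches the change from compound 1 to compound 3 `COc1ccc(N2C(=O)N(Cc3c(F)cc(C)cc3Cl)c3ccccc3S2(=O)=O)cc1OC`, which is still to be measured in this assay. The change is 2-chloro-6-fluoro-4-methylphenyl in place of 2,4,6-trifluorophenyl on a saturated chain carbon bound to an amide-type nitrogen in a ring. The 2,4,6-trifluorophenyl leaves and the 2-chloro-6-fluoro-4-methylphenyl enters on a saturated chain carbon bound to an amide-type nitrogen in a ring; both groups carry the same count of heavy atoms, with chlorine and methyl standing where two fluorines stood.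

Among the measured compounds shown here, with no comparable step in hand, the expected step of a 1.3-fold lower number from compound 1 to compound 3 (0.10 log units; within the scatter) is small, most likely within the scatter, and its direction is uncertain. For compound 3 the estimate in this assay is 40 nM, expected to fall between 10 nM and 160 nM.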

Compound 3, inhibition constant: 6.31 nM
Estimate against measurement, compound 3: 6.3-fold (0.80 log units) above; the whole stated range lies above it.
By their numbers in this assay, from the lowest: compound 2; then compound 3; then compound 1.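

In this assay, 2-chloro-6-fluoro-4-methylphenyl in place of 2,4,6-trifluorophenyl on a saturated chain carbon bound to an amide-type nitrogen in a ring gives a 7.9-fold lower number from compound 1 to compound 3 (0.90 log units; beyond the scatter). Among these compounds, this is the first single-place comparison, and it shows that this position is sensitive to the substitution on the phenyl even with the count of heavy atoms unchanged. No measurement at hand bears on the reason for this step.

As far as these compounds go, whether the chlorine, the methyl or the loss of the two fluorines carries the step remains open. Also open, from the compounds shown here alone, is how a carboxylic acid or a morpholine in place of the methyl would read in this assay, and whether 2-chloro-6-fluoro-4-methylbenzyl gives a similar step on the core of compound 2.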